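The source may hold more compounds than are shown below. What is called first, only, known or untested is meant among the compounds shown, and "the series" means these compounds.

Measured so far:
- compound 1, `O=C(Nc1cccc(-n2cc(-c3ccncc3)c(-c3ccc(Cl)c(O)c3)n2)c1)Nc1cccc(C(F)(F)F)c1` — 12000 nM
- compound 2, `COc1cc(-c2nn(-c3cccc(NC(=O)Nc4ccc(Cl)c(Cl)c4)c3)cc2-c2ccncc2)ccc1Cl` — 2440 nM

Both compounds were tested in a functional assay on RXF 393 cells (Homo sapiens) for inhibition, read by sulforhodamine B assay, with a stated time of 48 h; a lower number here means a stronger inhibitor of growth, a higher number a weaker inhibitor of growth. Compound 2 stands at the lower of the two numbers, and the gap to compound 1 is beyond the usual scatter, so compound 2 is the stronger growth inhibitor of the pair.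

The next compound, compound 3, `O=C(Nc1cccc(-n2cc(-c3ccncc3)c(-c3ccc(Cl)c(O)c3)n2)c1)Nc1ccc(Cl)c(Cl)c1`, comes from compound 2 by a single small change: hydrogen in place of methyl on an oxygen on an aromatic ring. In words, hydrogen in place of methyl on an oxygen on an aromatic ring, so that a methoxy becomes a hydroxy. Going by the values given here, no measured pair so far shows this particular change on its own, so there is no direct precedent to lean on. With only the two numbers at hand, the expectation is a modest step, most likely a small loss of potency or none beyond the scatter, and the estimated step of a 1.6-fold higher number from compound 2 to compound 3 (0.21 log units; within the scatter) reflects that. Compound 3 is expected to give about 4000 nM in this assay, within a range from 1500 nM to 12000 nM.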

Compound 3, concentration for total growth inhibition: 6400 nM
Compound 3: middle estimate off by 1.6-fold (0.20 log units), on the low side; the measured number falls inside the stated range.
By their numbers in this assay, from the lowest: compound 2; then compounds 3 and 1 (each within the scatter of the next).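

In this assay, hydrogen in place of methyl on the oxygen, turning 4-chloro-3-methoxyphenyl into 4-chloro-3-hydroxyphenyl, gives a 2.6-fold higher number from compound 2 to compound 3 (0.42 log units; beyond the scatter) and so shows that this position responds to a very small edit: losing a single methyl costs growth inhibition, at least with the 3,4-dichlorophenyl group in place. With the hydroxy kept, 3,4-dichlorophenyl in place of 3-(trifluoromethyl)phenyl on the amide-type nitrogen gives a 1.9-fold lower number from compound 1 to compound 3 (0.27 log units; within the scatter) and does not separate those two compounds, so at this level of potency that swap is not shown to matter. Nothing measured here accounts for either result.

On these data alone, the methoxy-to-hydroxy step rests on one pair, so it remains open whether it would be the same size with 3-(trifluoromethyl)phenyl on the other side of the molecule. Also open, as far as these compounds go, is how this position would respond to an ethoxy group or a longer chain on the oxygen, or to an amine in place of the oxygen, and whether any of these would match or pass the methoxy group.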